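Pyridin-3-yl to Pyridin-4-yl on a Shared Core

This account rests on a few compounds, and the source may have more. Where it says the series, first, only, none or still open, it means among the compounds named here.

In a functional assay on MIA PaCa-2 cells (Homo sapiens) for cytotoxicity, read by MTT assay, with a stated time of 4 h (on this read-out higher numbers stand for weaker inhibition and lower numbers for stronger inhibition), compound 1 `COC1=CC(=O)c2c(c(COc3ccccc3)c(C)n2C)C1=O` gives 1390 nM and compound 2 `COC1=CC(=O)c2c(c(COc3c(F)cc(F)cc3F)c(C)n2C)C1=O` gives 427 nM on the same core. Compound 3 `COC1=CC(=O)c2c(c(COc3cccnc3)c(C)n2C)C1=O` gives 904 nM as a number within the scatter of compound 1 and higher than that of compound 2. Compound 4 `COC1=CC(=O)c2c(c(COc3ccncc3)c(C)n2C)C1=O` carries pyridin-4-yl in place of pyridin-3-yl on an oxygen on a saturated carbon and is otherwise unchanged. Among the measured compounds shown here, the one measured step that bears on this is a 1.5-fold lower number from compound 1 to compound 3 (0.19 log units; within the scatter) (phenyl to pyridin-3-yl), which lies within the scatter. For the measured compounds named here, no measured pair compares the two pyridinyl groups directly, so no step beyond the scatter is expected in either direction. The estimated step is a 1.0-fold lower number from compound 3 to compound 4 (0.00 log units; within the scatter) in size. Compound 4 is estimated at 900 nM in this assay with a range of 420 nM to 1900 nM expected around it.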

Compound 4, half-maximal inhibitory concentration: 2010 nM
Compound 4: the middle estimate sits 2.2-fold (0.35 log units) below what was measured, outside the stated range (above it).
By their numbers in this assay, from the lowest: compound 2; then compounds 3, 1 and 4 (each within the scatter of the next, the first and the last beyond it).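

In this assay, putting pyridin-4-yl in place of pyridin-3-yl on an oxygen on a saturated carbon gives a 2.2-fold higher number from compound 3 to compound 4 (0.35 log units; beyond the scatter), so two groups with the same atoms, joined differently, can be told apart here. Pyridin-4-yl in place of phenyl gives a 1.4-fold higher number from compound 1 to compound 4 (0.16 log units; within the scatter), so neither pyridinyl group is set apart from phenyl, given a 1.5-fold lower number from compound 1 to compound 3 (0.19 log units; within the scatter) for the other one. Nothing available explains the gap between the two pyridinyl groups.

The compounds shown leave open how pyridin-2-yl would read at this place, and whether an amine or a carboxylic acid on the pyridin-4-yl ring would shift its number.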